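Fluorine on the Benzyl Ring of Compound 3

The source may report more compounds than this note shows. Statements on the series, on what has been measured and on what is new or still open speak of the compounds shown alone.

This series shares one core. Compound 1 `O=C1COCCN1c1ccc(/N=C\c2c[nH]c3ccccc23)cc1` carries a hydrogen on its aromatic nitrogen; compound 2 `O=C1COCCN1c1ccc(/N=C\c2cn(C(=O)c3ccc(Cl)cc3)c3ccccc23)cc1` carries a (4-chlorophenyl)carbonyl there, and compound 3 `O=C1COCCN1c1ccc(/N=C\c2cn(Cc3ccccc3)c3ccccc23)cc1` a benzyl. In an ADME assay on BV-2 cells (Mus musculus) for cytotoxicity, read by MTT assay, with a stated time of 48 h, tested at 100 uM (a higher number here means a weaker effect of the compound at the concentration tested, a lower number a stronger effect), compound 1 gives 101%, compound 2 gives 80.5% and compound 3 gives 56.2%. Compound 3 therefore stands lowest of the three in this assay, with a number 24.3 percentage points lower from compound 2 to compound 3 (beyond the scatter) and a number 44.8 percentage points lower from compound 1 to compound 3 (beyond the scatter), so it shows the strongest effect at the concentration tested.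

Compound 4 `O=C1COCCN1c1ccc(/N=C\c2cn(Cc3ccc(F)cc3)c3ccccc23)cc1` differs from compound 3 by fluoro in place of hydrogen on an aromatic carbon on the benzyl group. Among the compounds with values here, none of the measured steps changes a substituent on that ring: the steps of a number 20.5 percentage points lower from compound 1 to compound 2 (beyond the scatter) and a number 44.8 percentage points lower from compound 1 to compound 3 (beyond the scatter) replace the hydrogen on the nitrogen, and compound 2 alone carries a chlorine, which cannot be separated from its carbonyl. No step beyond the scatter is therefore expected for a number 1.2 percentage points lower from compound 3 to compound 4 (within the scatter), and compound 4 is estimated at 55%, between 40% and 70%.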

Compound 4, a percentage reported as activity, at one concentration (the size of the read-out at that concentration, not a potency): 55.5%
The estimate for compound 4 lay 0.5 percentage points below the measured number; the measured number falls inside the stated range.
By their numbers in this assay, from the lowest: compounds 4 and 3 (each within the scatter of the next); then compound 2; then compound 1.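

In this assay, within the data shown here, this is the first change made on the benzyl ring itself rather than on the aromatic nitrogen, and fluoro in place of hydrogen, para to a large group, gives a number 0.7 percentage points lower from compound 3 to compound 4 (within the scatter), so the two compounds cannot be told apart. The larger differences still follow the group on the nitrogen: 4-fluorobenzyl in place of (4-chlorophenyl)carbonyl gives a number 25 percentage points lower from compound 2 to compound 4 (beyond the scatter), and 4-fluorobenzyl in place of hydrogen gives a number 45.5 percentage points lower from compound 1 to compound 4 (beyond the scatter). Nothing available here offers a reason for these numbers.

As far as these compounds go, one fluoro at one place says little about the ring as a whole, so it remains open whether a chlorine, a methoxy group, an amine or a carboxylic acid there would also stay within the scatter. From the compounds shown here alone, how a longer chain in place of the benzyl group on the nitrogen would read also remains open.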